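The source may hold more compounds than are shown below. What is called first, only, known or untested is meant among the compounds shown, and "the series" means these compounds.

In an ADME assay on microsomes from liver (Mus musculus) for metabolic stability (a lower number here means that the compound disappears faster, a higher number that the compound lasts longer), compound 1 (`NS(=O)(=O)CC(=O)NCCSc1nonc1/C(=N/O)Nc1cccc(C(F)F)c1`) gives 1.5 h, compound 2 (`NS(=O)(=O)CC(=O)NCCSc1nonc1/C(=N/O)Nc1ccc(F)c(C(F)F)c1`) gives 1.07 h, and compound 3 (`O=C(NCCSc1nonc1/C(=N/O)Nc1ccc(F)c(C(F)F)c1)C1CS(=O)(=O)C1`) gives 0.245 h, the lowest of the three numbers. Compound 4 (`CC(C)(O)CC(=O)NCCSc1nonc1/C(=N/O)Nc1ccc(F)c(C(F)F)c1`) differs from compound 3 by a group of 5 heavy atoms (4 carbon, 1 oxygen; no ring) in place of a group of 6 heavy atoms (3 carbon, 2 oxygen, 1 sulfur; one four-membered non-aromatic ring with 1 hetero atom), on a carbonyl carbon, so that 2-hydroxy-2-methylpropyl stands on the carbonyl carbon. The most relevant measured change is a 4.4-fold lower number from compound 2 to compound 3 (0.64 log units; beyond the scatter), made at this same place. The other, a 1.4-fold lower number from compound 1 to compound 2 (0.15 log units; within the scatter), does not touch this place. Within the data shown here, no measured compound carries the entering group, so only a partial recovery toward the number of compound 2 is expected in this assay, and that expectation is loose. The expected change is a 2.4-fold higher number from compound 3 to compound 4 (0.39 log units; beyond the scatter). For compound 4, the estimated half-life is 0.6 h, with an expected range of 0.2 h to 1.6 h.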

Compound 4, half-life: 0.175 h
Estimate against measurement, compound 4: 3.4-fold (0.54 log units) above; measured number below the stated range.
By their numbers in this assay, from the lowest: compounds 4 and 3 (each within the scatter of the next); then compounds 2 and 1 (each within the scatter of the next).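

In this assay, placing 2-hydroxy-2-methylpropyl on the carbonyl carbon gives a 1.4-fold lower number from compound 3 to compound 4 (0.15 log units; within the scatter) and so does not separate this group from the ring-bearing group of compound 3. Against the sulfamoyl-bearing side chain, the same position gives a 6.1-fold lower number from compound 2 to compound 4 (0.79 log units; beyond the scatter), so a second replacement also lies beyond the scatter from compound 2. Nothing available accounts for this result. As far as these compounds go, whether an amine, a carboxylic acid or a longer chain on this carbonyl carbon would stay closer to compound 2 remains open.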